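Swapping the Ring on the Piperidine Nitrogen

The source may report more compounds than this note shows. Statements on the series, on what has been measured and on what is new or still open speak of the compounds shown alone.

Compounds measured so far:
Compound 1 `CN(C)c1ccc(C(=O)N2CCC(NS(=O)(=O)c3cc(S(=O)(=O)c4ccccc4)ccc3C(F)(F)F)CC2)cc1` in an assay on U2OS cells for inhibition of secreted frizzled-related protein 1 (Homo sapiens), read by a luciferase reporter, with a stated time of 18 h (on this read-out higher numbers stand for an effect only at larger amounts of compound and lower numbers for an effect already at smaller amounts), gives 190 nM.
Compound 2 `N#Cc1cccc(S(=O)(=O)N2CCC(NS(=O)(=O)c3cc(S(=O)(=O)c4ccccc4)ccc3C(F)(F)F)CC2)c1` in this assay gives 170 nM.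

Compound 2 shows the lowest of the two numbers, but the step of a 1.1-fold lower number from compound 1 to compound 2 (0.05 log units; within the scatter) is within the scatter, so the two cannot be ranked. Compound 3 `O=C(C1CCNCC1)N1CCC(NS(=O)(=O)c2cc(S(=O)(=O)c3ccccc3)ccc2C(F)(F)F)CC1` is not yet measured. It differs from compound 2 by (piperidin-4-yl)carbonyl in place of (3-cyanophenyl)sulfonyl on an amine nitrogen in a ring. Among the compounds with values here, the only measured step at this position, a 1.1-fold lower number from compound 1 to compound 2 (0.05 log units; within the scatter), exchanged one aromatic ring for another and hardly moved the number; no step shows a non-aromatic ring here. A modest weakening is therefore expected for compound 3, a 2.4-fold higher number from compound 2 to compound 3 (0.37 log units; beyond the scatter), with an estimate of 400 nM, between 120 nM and 1500 nM.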

Compound 3, half-maximal effective concentration: 150 nM
Estimate against measurement, compound 3: 2.7-fold (0.43 log units) above, within the range that was stated.
By their numbers in this assay, from the lowest: compounds 3, 2 and 1 (each within the scatter of the next).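

Until now only aromatic rings had stood on this amine nitrogen in a ring. The (piperidin-4-yl)carbonyl group, with its non-aromatic ring, gives a 1.1-fold lower number from compound 2 to compound 3 (0.05 log units; within the scatter) against (3-cyanophenyl)sulfonyl, and piperidin-4-yl on a carbonyl carbon gives a 1.3-fold lower number from compound 1 to compound 3 (0.10 log units; within the scatter) against 4-(dimethylamino)phenyl, so across these three compounds an aromatic ring at this place is not needed to keep the number in this range. Nothing measured here gives a reason for this. On these data alone, whether a group without any ring, such as a plain acetyl or a longer alkyl chain, would hold the number stays open. So does the outcome of placing a carboxylic acid on the piperidin-4-yl ring.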